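Pyridazinone amides on a thienopyrimidine ether: cytotoxicity notes

A few compounds are considered here, and "the series" means these few. Any claim that something is new, unique, unknown or untested is made for them only; others in the source may bear on it.

Values in a functional assay on HepG2 cells (Homo sapiens) for cytotoxicity, read by MTT assay, with a stated time of 72 h; a higher number here means a weaker inhibitor, a lower number a stronger inhibitor:
- compound 1, `Cc1cc(=O)n(-c2ccc(Br)cc2F)nc1C(=O)Nc1ccc(Oc2ncnc3ccsc23)cc1`, gives 10600 nM
- compound 2, `Cc1cc(=O)n(-c2ccccc2OC(F)(F)F)nc1C(=O)Nc1ccc(Oc2ncnc3ccsc23)cc1`, gives 25000 nM
- compound 3, `Cc1cc(=O)n(-c2ccc(Br)cc2F)nc1C(=O)Nc1ccc(Oc2ncnc3sccc23)c(F)c1`, gives 13800 nM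

One single-point change is measured: 2-(trifluoromethoxy)phenyl in place of 4-bromo-2-fluorophenyl on an aromatic nitrogen, which gives a 2.4-fold higher number from compound 1 to compound 2 (0.37 log units; beyond the scatter). Compound 3 carries a different core from compound 1; how the two cores differ is not broken down here, and the numbers of compound 3 lie within the scatter of both compound 1 and compound 2, so no order among them is claimed.

Compound 4, `Cc1cc(=O)n(-c2ccccc2OC(F)(F)F)nc1C(=O)Nc1ccc(Oc2ncnc3sccc23)c(F)c1`, is not yet measured. It differs from compound 3 by 2-(trifluoromethoxy)phenyl in place of 4-bromo-2-fluorophenyl on an aromatic nitrogen, the same change as from compound 1 to compound 2. The step of a 2.2-fold higher number from compound 3 to compound 4 (0.34 log units; beyond the scatter) is expected to sit beside a 2.4-fold higher number from compound 1 to compound 2 (0.37 log units; beyond the scatter), resting on that single earlier step and on compound 3 at 13800 nM. Compound 4 is therefore estimated at 30000 nM, between 12000 nM and 75000 nM.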

Compound 4, half-maximal inhibitory concentration: > 40000 nM
Compound 4: no number, only a limit; the forecaster's own chance of this, stated with the estimate: 15%; at least 1.3-fold (0.12 log units) between middle value and limit.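

In this assay compound 4 gives > 40000 nM, which is a limit of the assay and not a number. With 2-(trifluoromethoxy)phenyl in place of 4-bromo-2-fluorophenyl on the aromatic nitrogen, the step is an at least 2.8-fold higher number from compound 3 to compound 4 (0.46 log units; beyond the scatter), so the change moves the number the same way on both cores: the same change on two cores in this assay, a 2.4-fold higher number (0.37 log units; beyond the scatter) from compound 1 to compound 2 and an at least 2.8-fold higher number (0.46 log units; beyond the scatter) from compound 3 to compound 4; the limit leaves it open whether they differ This shows the direction carrying over between these two cores only; it does not show that the size carries over, since the step on the core of compound 3 has only a lower bound.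

Also open, on these data alone, is whether the direction would hold for other groups on the aromatic nitrogen, such as a phenyl ring bearing a carboxylic acid or an amine. The compounds shown also leave open how the two cores themselves compare when only the core differs.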